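A few compounds are considered here, and "the series" means these few. Any claim that something is new, unique, unknown or untested is made for them only; others in the source may bear on it.

Compound 1 `CS(=O)(=O)c1ccc2nc(NC(=O)CCCCCCC(=O)NO)sc2c1` gives 5.42 ug/mL in a functional assay on SW-620 cells (Homo sapiens) for cytotoxicity; a higher number here means a weaker inhibitor, a lower number a stronger inhibitor. Compound 3 `CCOc1ccc2nc(NC(=O)CCCCCCC(=O)NO)sc2c1` gives 10.4 ug/mL in this assay, the step of a 1.9-fold higher number from compound 1 to compound 3 (0.28 log units; within the scatter). Compound 2 `CS(=O)(=O)c1ccc2nc(NC(=O)CCCCC(=O)NO)sc2c1` gives only a limit in this assay, > 30 ug/mL. That limit is the limit of > 30 ug/mL in this assay, at which 1 of the 3 values shown sits, so compound 2 stands at the weak end of the numbers shown, reached by the step of an at least 5.5-fold higher number from compound 1 to compound 2 (0.74 log units; beyond the scatter). Compound 4 `O=C(CCCCC(=O)Nc1nc2ccccc2s1)NO` is not yet measured; it differs from compound 2 by hydrogen in place of methylsulfonyl on an aromatic carbon. Among the compounds with values here, no measured step removes this group outright; the nearest is the exchange of methylsulfonyl for ethoxy, a 1.9-fold higher number from compound 1 to compound 3 (0.28 log units; within the scatter), which stayed within the scatter. No step beyond the scatter is therefore expected in this assay. Compound 4 is estimated at 40 ug/mL, between 15 ug/mL and 100 ug/mL. The expected step is a step that the limit leaves unreadable from compound 2 to compound 4, most likely again only a limit.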

Compound 4, half-maximal inhibitory concentration: 7.85 ug/mL
Estimate against measurement, compound 4: 5.1-fold (0.71 log units) above; the measured number lies below the stated range.
By their numbers in this assay, from the lowest: compounds 1, 4 and 3 (each within the scatter of the next). At a limit, above all of these: compound 2.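

In this assay, hydrogen in place of methylsulfonyl on an aromatic carbon, with the chain of compound 2 kept, is a step beyond the scatter, an at least 3.8-fold lower number from compound 2 to compound 4 (0.58 log units; beyond the scatter), whereas the exchange of methylsulfonyl for ethoxy on the chain of compound 1 stayed within it. Substitution at this position can therefore matter, at least with the chain of compound 2. Compound 2 stands at a limit, so the step gives only a lower bound on the change: the limit of > 30 ug/mL in this assay, at which 1 of the 4 values shown sits.

Open, as far as these compounds go, is whether hydrogen at this position would give a step of similar size on the chain of compound 1. Also open, from the compounds shown here alone, is how an amine or a carboxylic acid on this aromatic carbon would read.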